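Compound 3 to compound 4: a carbonyl substituent change

This account rests on a few compounds, and the source may have more. Where it says the series, first, only, none or still open, it means among the compounds named here.

Compound 1 `NNC(=O)CCc1ccncc1-c1ccc2ccccc2c1` gives > 30000 nM in a functional assay on HCT-116 cells (Homo sapiens) for inhibition, read by MTT assay, with a stated time of 72 h (on this read-out lower numbers stand for stronger inhibition of growth and higher numbers for weaker inhibition of growth), which is a limit of the assay. Compound 2 `O=C(O)COc1ccncc1-c1ccc2ccccc2c1` has the entry "not determined" (no result reported). Compound 3 `COC1CN(C(=O)/C=C/c2ccncc2-c2ccc3ccccc3c2)C1` gives > 30000 nM, again only a limit. Within the data shown here, the one recurring result is the limit of > 30000 nM in this assay, at which 2 of the 3 values shown sit, and no compound has yet given a single number.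

Compound 4 `COC(=O)/C=C/c1ccncc1-c1ccc2ccccc2c1` has methoxy in place of 3-methoxyazetidin-1-yl on a carbonyl carbon. No measured step sizes this change in this assay, so no shift beyond the scatter is expected, and no direction is favoured. The expected change is an at least 1.2-fold lower number from compound 3 to compound 4 (0.07 log units; that floor lies within the scatter). For compound 4 the estimated value is 25000 nM, with an expected range of 8000 nM to 50000 nM.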

Compound 4, concentration for 50% growth inhibition: 350 nM
The estimate for compound 4 lay 71-fold (1.85 log units) above the measured number; measured number outside the range, below it.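

In this assay the carbonyl carbon proves sensitive to its substituent: methoxy in place of 3-methoxyazetidin-1-yl gives an at least 85-fold lower number from compound 3 to compound 4 (1.93 log units; beyond the scatter). Placing 2-(methoxycarbonyl)ethenyl in place of 2-(aminocarbamoyl)ethyl on the aromatic carbon gives an at least 85-fold lower number from compound 1 to compound 4 (1.93 log units; beyond the scatter). Compound 4 is the only compound shown with a single number rather than a limit: the limit of > 30000 nM in this assay, at which 2 of the 4 values shown sit.

As far as these compounds go, both steps start from a limit, so their full size stays unknown. Also open is whether methoxy itself is needed, since ethoxy or an unsubstituted amino group on the same carbonyl carbon does not appear among the compounds shown.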